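Trimming one more methyl from the dienyl side chain

The source may hold more compounds than are shown below. What is called first, only, known or untested is meant among the compounds shown, and "the series" means these compounds.

Two compounds of this series have numbers in a functional assay on the whole organism with Canis familiaris (Canis lupus familiaris) as the target; a lower number here means that less compound is needed, a higher number that more compound is needed for the effect. Compound 1 `COC(=O)CC/C=C\CC[C@H]1C(=O)C[C@@H](O)[C@@H]1/C=C/C[C@@](C)(O)/C=C/C(C)=C(C)C` gives 0.00006 mg/kg, and compound 2 `C/C=C(C)/C=C/[C@](C)(O)C/C=C/[C@H]1[C@H](O)CC(=O)[C@@H]1CC/C=C\CCC(=O)OC` gives 0.000003 mg/kg, the lower of the two. Compound 3 `C/C=C/C=C/[C@](C)(O)C/C=C/[C@H]1[C@H](O)CC(=O)[C@@H]1CC/C=C\CCC(=O)OC` departs from compound 2 in a single place: hydrogen in place of methyl on a double-bonded chain carbon bound to two double-bonded chain carbons. This is hydrogen in place of methyl on a double-bonded chain carbon bound to two double-bonded chain carbons, so that 1-methylprop-1-en-1-yl becomes prop-1-en-1-yl.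

Going by the values given here, the only measured step that bears on this is a 20-fold lower number from compound 1 to compound 2 (1.30 log units; beyond the scatter), which is large and also replaces a methyl with hydrogen, though at a different place. A single step makes no trend, and it cannot be assumed to repeat at a new carbon. As far as these compounds go, the direction therefore stays open, and a smaller change is expected here, perhaps none beyond the scatter. The expected step is a 2.0-fold higher number from compound 2 to compound 3 (0.30 log units; within the scatter). Compound 3 is estimated at 0.000006 mg/kg, with an expected range of 0.0000008 mg/kg to 0.00004 mg/kg.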

Compound 3, dose for half-maximal effect: 0.00003 mg/kg
Compound 3: the middle estimate sits 5.0-fold (0.70 log units) below what was measured; measured number inside the range.
By their numbers in this assay, from the lowest: compound 2; then compounds 3 and 1 (each within the scatter of the next).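

In this assay the methyl on this double-bonded chain carbon bound to two double-bonded chain carbons proves to matter, since losing it gives a 10-fold higher number from compound 2 to compound 3 (1.00 log units; beyond the scatter) and so takes the number away from that of compound 2. Trimming a methyl from the dienyl side chain therefore has no single direction in this series: the earlier step was a 20-fold lower number from compound 1 to compound 2 (1.30 log units; beyond the scatter) while the new one runs the opposite way, which leaves 1-methylprop-1-en-1-yl with the lowest number of the three side chains. The direct comparison of the other two side chains gives a 2.0-fold lower number from compound 1 to compound 3 (0.30 log units; within the scatter) and lies within the scatter, so prop-1-en-1-yl, with neither methyl, and 1,2-dimethylprop-1-en-1-yl, with both, cannot be told apart here.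

Nothing given here explains why the two methyl changes pull in opposite directions. Also open, as far as these compounds go, is whether an ethyl or a methoxy group on this same double-bonded chain carbon would hold the number near that of compound 2 or move it towards that of compound 3, and whether the effect of this methyl would carry over to a side chain without the hydroxyl group.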